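A few compounds are considered here, and "the series" means these few. Any claim that something is new, unique, unknown or untested is made for them only; others in the source may bear on it.

Measured so far:
- compound 1, `CC1=NC(C)=C(C(=O)O)C(c2cccc(Cl)c2)/C1=C(\O)OC/C=C/c1ccc(Cl)cc1`: 1500 nM
- compound 2, `CC1=NC(C)=C(C(=O)O)C(c2cccc(Cl)c2)/C1=C(\O)OC/C=C/c1ccc(C)cc1`: 890 nM
- compound 3, `CC1=NC(C)=C(C(=O)O)C(c2cccc(Cl)c2)/C1=C(\O)OC/C=C/c1ccncc1`: 6200 nM

In a functional assay on IMR-32 cells for inhibition of Voltage-dependent N-type calcium channel subunit alpha-1B (Homo sapiens), read by calcium flux (on this read-out higher numbers stand for weaker inhibition and lower numbers for stronger inhibition), compound 3 gives the highest of the three numbers; its nearest neighbour is compound 1 and its furthest is compound 2, both beyond the scatter. Compound 4, `CC1=NC(C)=C(C(=O)O)C(c2cccc(Cl)c2)/C1=C(\O)OCC(=O)Nc1ccccc1`, differs from compound 3 by phenylcarbamoyl in place of 2-(pyridin-4-yl)ethenyl on a saturated chain carbon bound to an oxygen on an unsaturated carbon. Going by the values given here, no measured step carries this exact change; the steps that bear on the same place are a 4.1-fold higher number from compound 1 to compound 3 (0.62 log units; beyond the scatter) and a 7.0-fold higher number from compound 2 to compound 3 (0.84 log units; beyond the scatter), both modest, showing that the aromatic group on that chain shifts this assay beyond the scatter. A step of a 3.4-fold lower number from compound 3 to compound 4 (0.54 log units; beyond the scatter) is therefore expected, back toward the numbers of compound 1 and compound 2. Compound 4 is estimated at 1800 nM, between 500 nM and 6500 nM.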

Compound 4, half-maximal inhibitory concentration: 28000 nM
Beside the measured number, compound 4's estimate is 16-fold (1.19 log units) below it, and the stated range ends below it.
By their numbers in this assay, from the lowest: compounds 2 and 1 (each within the scatter of the next); then compound 3; then compound 4.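

In this assay, going by these compounds alone, the link between the aromatic ring and the saturated chain carbon matters more than the earlier compounds showed: phenylcarbamoyl in place of the ethenyl-linked groups gives a 4.5-fold higher number from compound 3 to compound 4 (0.65 log units; beyond the scatter), a 19-fold higher number from compound 1 to compound 4 (1.27 log units; beyond the scatter) and a 31-fold higher number from compound 2 to compound 4 (1.50 log units; beyond the scatter). A ring of carbon only does not hold the number on its own, since compound 4 carries one and still gives the highest number of the four. Nothing available explains this shift.

As far as these compounds go, it remains open whether a 4-chloro or 4-methyl group on the phenyl ring would recover inhibition with the phenylcarbamoyl group in place. Also open, from the compounds shown here alone, is how an ester in place of the amide, or a saturated ethyl link in place of the ethenyl, would read.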